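Dropping One Methoxy from Two Related Sulfonyl Piperidinones

The source may report more compounds than this note shows. Statements on the series, on what has been measured and on what is new or still open speak of the compounds shown alone.

Compound 1 `COc1cc(/C=C2\CN(S(=O)(=O)c3ccc(F)cc3)C/C(=C\c3cc(OC)c(OC)c(OC)c3)C2=O)cc(OC)c1OC` and compound 3 `COc1cc(/C=C2\CN(S(=O)(=O)c3ccc(NC(C)=O)cc3)C/C(=C\c3ccccc3F)C2=O)cc(OC)c1OC` share much of their build, but the difference between the two cores is not broken down here. In a functional assay on HepG2 cells (Homo sapiens) for cytotoxicity, read by MTT assay, with a stated time of 24 h (on this read-out higher numbers stand for weaker inhibition and lower numbers for stronger inhibition), compound 1 gives 4200 nM, and compound 3 gives 4750 nM. Compound 2 `COc1cc(/C=C2\CN(S(=O)(=O)c3ccc(F)cc3)C/C(=C\c3cc(OC)c(OC)c(OC)c3)C2=O)cc(OC)c1` arises from compound 1 by hydrogen in place of methoxy on an aromatic carbon. In this assay compound 2 gives 3890 nM, so the step of a 1.1-fold lower number from compound 1 to compound 2 (0.03 log units; within the scatter) hardly moves the number at all.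

Compound 4 `COc1cc(/C=C2\CN(S(=O)(=O)c3ccc(NC(C)=O)cc3)C/C(=C\c3ccccc3F)C2=O)cc(OC)c1` has not yet been measured. It comes from compound 3 by hydrogen in place of methoxy on an aromatic carbon, which is the same change at the same kind of place as the one already seen. Going by the values given here, the measured step of a 1.1-fold lower number from compound 1 to compound 2 (0.03 log units; within the scatter) stayed within the scatter, and that single earlier pair is the only guide available here. On that basis the expected step for compound 4 in this assay is about a 1.1-fold lower number from compound 3 to compound 4 (0.03 log units; within the scatter). Compound 4 is therefore estimated to give about 4400 nM in this assay, most likely falling between 2400 nM and 8000 nM.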

Compound 4, half-maximal inhibitory concentration: 6800 nM
The estimate for compound 4 lay 1.5-fold (0.19 log units) below the measured number; the measured number falls inside the stated range.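

Replacing the methoxy with hydrogen, which turns 3,4,5-trimethoxyphenyl into 3,5-dimethoxyphenyl, gives a 1.4-fold higher number from compound 3 to compound 4 (0.16 log units; within the scatter) in this assay. Set beside the earlier case, the change shows no measurable difference between the two cores: the same change on two cores in this assay, a 1.1-fold lower number (0.03 log units; within the scatter) from compound 1 to compound 2 and a 1.4-fold higher number (0.16 log units; within the scatter) from compound 3 to compound 4, 1.5-fold (0.19 log units) apart, within the scatter of two such steps. This means that in these two pairs the methoxy can be swapped for hydrogen without a step that stands out from ordinary measurement noise, but two pairs are a small sample, so this does not establish a rule for other cores in the series, nor does it show that the methoxy has no role in other assays.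

The compounds shown leave open what happens when that same aromatic carbon carries a group other than methoxy or hydrogen, such as a hydroxyl, an amine or a longer chain like butoxy. They also leave open whether removing the two remaining methoxy groups would give a larger step.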